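This account rests on a few compounds, and the source may have more. Where it says the series, first, only, none or still open, it means among the compounds named here.

Compound 1 `C#C[C@]1(CO)O[C@@H](n2cc(Cl)c(=O)[nH]c2=O)C[C@@H]1O`: 81700 nM
Compound 2 `C#C[C@]1(CO)O[C@@H](n2cc(C)c(N)nc2=O)C[C@@H]1O`: 700 nM

Measured in a functional assay on MT4 cells (Homo sapiens), read by MTT assay (on this read-out higher numbers stand for lower toxicity in this test and lower numbers for higher toxicity in this test), compound 2 stands at 700 nM, the lower of the two numbers and thus the higher toxicity in this test. The gap up to compound 1 lies beyond the usual scatter.

The next compound, compound 3 `C#C[C@]1(CO)O[C@@H](n2cc(Cl)c(N)nc2=O)C[C@@H]1O`, has not yet been measured. It has chloro in place of methyl on an aromatic carbon, and the rest of compound 2 stays as it is: chloro in place of methyl on an aromatic carbon. Within the data shown here, no step between measured compounds isolates this change, so the data give no direct guide to its size. Compound 1, at 81700 nM, also carries a chloro, but it is not a single-change neighbour of compound 3 and offers only a weak hint of direction.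

A modest rise in the number is therefore expected in this assay, though a step within the scatter remains quite possible. The expected change is a 2.1-fold higher number from compound 2 to compound 3 (0.33 log units; beyond the scatter). The estimated value for compound 3 is 1500 nM, with an expected range from 250 nM to 9000 nM.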

Compound 3, half-maximal cytotoxic concentration: > 100000 nM
Compound 3 was reported as a limit; the forecaster's own chance of this, stated with the estimate: 5%; middle value at least 66-fold (1.82 log units) from the limit.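

In this assay, exchanging methyl for chloro on the aromatic carbon ortho to the amino group gives an at least 140-fold higher number from compound 2 to compound 3 (2.15 log units; beyond the scatter), a large step beyond the usual scatter. Among these compounds, compound 3 gives > 100000 nM, which is a limit of the assay and not a number, so the step has a known minimum but no known end: the limit of > 100000 nM in this assay, at which 1 of the 3 values shown sits. This is the first pair that isolates this position, and it shows that this one exchange, with the rest of compound 2 unchanged, is enough to move the read-out from the higher toxicity in this test to the far lower toxicity end of what the assay can report.

From the compounds shown here alone, whether the low number of compound 2 is particular to methyl, or would also appear with another group at this position, such as ethyl, bromo or a plain hydrogen, remains open. The data also give no cause for the step, and they cannot tell how far the true value of compound 3 lies past its limit.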